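The compounds below may be only part of what the source reports. "The series", "measured", "known", "first", "only" and "open" are said of these compounds alone.

Working notes on the series. Compound 2, `Nc1cc(N)c2nc(-c3ccccc3)c(Oc3ccc(F)cc3)nc2c1`, carries the shared core with a phenyl group and a 4-fluorophenoxy group. Its neighbour compound 1, `COc1ccc(Sc2nc3cc(N)cc(N)c3nc2-c2ccccc2)cc1`, differs only in that the same position bears a (4-methoxyphenyl)sulfanyl group. In a functional assay on M14 cells (Homo sapiens) for inhibition, read by sulforhodamine B assay, with a stated time of 48 h (on this read-out lower numbers stand for higher toxicity in this test and higher numbers for lower toxicity in this test), compound 1 gives < 100000 nM, which is a limit of the assay and not a number. In this assay compound 2 likewise gives < 100000 nM, again a limit. Hence the one measured step, a step that the two limits leave unreadable from compound 1 to compound 2, cannot be sized, and the whole body of evidence rests on (the limit of < 100000 nM in this assay, at which 2 of the 2 values shown sit). Compound 3, `Nc1cc(N)c2nc(-c3ccccc3)c(Sc3ccc(F)cc3)nc2c1`, is not yet measured; it differs from compound 2 by (4-fluorophenyl)sulfanyl in place of 4-fluorophenoxy on an aromatic carbon. Within the data shown here, no measured step reads out a size for this kind of change. Compound 3 is therefore expected to sit near compound 2, at an estimated 60000 nM with a range of 15000 nM to 100000 nM, most likely reported as a limit. The step from compound 2 to compound 3 is thus expected to be a step that the limit leaves unreadable from compound 2 to compound 3, with no direction readable beyond the scatter.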

Compound 3, concentration lethal to 50% of the cells: 58900 nM
Estimate against measurement, compound 3: 1.0-fold (0.01 log units) above; the range from low to high includes it.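

No new step can be read: compound 3 has a measured value, but compound 1 and compound 2 stand only at limits of the assay, not at numbers, so every step among the three stays unsized: the limit of < 100000 nM in this assay, at which 2 of the 3 values shown sit.

The compounds shown leave open whether (4-fluorophenyl)sulfanyl in place of 4-fluorophenoxy, or fluoro in place of methoxy, shifts the read-out at all, and in which direction.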